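Replacing chloro with trifluoromethyl in compound 1

The source may report more compounds than this note shows. Statements on the series, on what has been measured and on what is new or still open speak of the compounds shown alone.

Compound 1 `O=C(NCc1ccccc1Cl)N1C(=O)c2ccccc2S1(=O)=O`: > 166 h
Compound 2 `O=C(NCc1cccs1)N1C(=O)c2ccccc2S1(=O)=O`: > 166 h

In a physicochemical assay for pharmacokinetics (a lower number here means that the compound disappears faster, a higher number that the compound lasts longer), compound 1 gives > 166 h, which is a limit and not a number. Compound 2 gives > 166 h, which is likewise a limit. The picture so far therefore consists of the limit of > 166 h in this assay, at which 2 of the 2 values shown sit.

Among the compounds with values here, the only measured step, a step that the two limits leave unreadable from compound 1 to compound 2, has no size that could be carried over to a new change. Compound 3 `O=C(NCc1ccccc1C(F)(F)F)N1C(=O)c2ccccc2S1(=O)=O` differs from compound 1 by trifluoromethyl in place of chloro on an aromatic carbon, with trifluoromethyl in place of chloro on an aromatic carbon. With no readable step to draw on, no change beyond the scatter is expected in this assay, and another limit is the likeliest reading. The estimated step is a step that the limit leaves unreadable from compound 1 to compound 3. For compound 3 the expected half-life is 200 h, with an estimated range of 120 h to 400 h.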

Compound 3, half-life: > 166 h
Compound 3: no number, only a limit (the forecaster's own chance of this, stated with the estimate: 80%); the middle value is on the limit's open side.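

In this assay compound 3 gives > 166 h, which is a limit and not a number. No step can be read between compound 1 and compound 3. The compounds shown leave open whether trifluoromethyl in place of chloro changes the half-life at all, and all values remain limits: the limit of > 166 h in this assay, at which 3 of the 3 values shown sit.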